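The source may hold more compounds than are shown below. What is called first, only, known or untested is meant among the compounds shown, and "the series" means these compounds.

In a functional assay on PC-3 cells (Homo sapiens) for antiproliferative activity, read by WST assay, with a stated time of 3 days (on this read-out higher numbers stand for weaker inhibition and lower numbers for stronger inhibition), compound 2 `CCC(C)Oc1c(-c2cc(OC)c(OC)c(OC)c2)oc2ccccc2c1=O` gives 38600 nM. Within the data shown here, it cannot be told apart from its only measured neighbour, compound 1 `COc1cc(-c2oc3ccccc3c(=O)c2OC(C)C)cc(OC)c1OC`, which gives 21200 nM. Compound 3 `CCN(CC)CCCCOc1c(-c2cc(OC)c(OC)c(OC)c2)oc2ccccc2c1=O` keeps the shared core and alters one side chain: 4-(diethylamino)butyl in place of sec-butyl on an oxygen on an aromatic ring. In words, this places 4-(diethylamino)butyl in place of sec-butyl on an oxygen on an aromatic ring. Among the measured compounds shown here, the only measured step that bears on this is a 1.8-fold higher number from compound 1 to compound 2 (0.26 log units; within the scatter), and it involves just one methyl in place of hydrogen on a saturated chain carbon. The new change is much larger, so that step sets no size for it, and nothing measured here fixes a direction. A tentative, moderate move towards stronger inhibition is expected, a 4.3-fold lower number from compound 2 to compound 3 (0.63 log units; beyond the scatter), with wide uncertainty. For compound 3 the estimate is 9000 nM, with an expected range from 2000 nM to 40000 nM.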

Compound 3, half-maximal inhibitory concentration: 13700 nM
For compound 3 the middle estimate is 1.5-fold (0.18 log units) below the measured one, and the stated range covers the measured number.
By their numbers in this assay, from the lowest: compounds 3, 1 and 2 (each within the scatter of the next, the first and the last beyond it).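

At this position, on an oxygen on an aromatic ring, a much larger chain carrying a nitrogen is accepted in this assay: 4-(diethylamino)butyl in place of sec-butyl gives a 2.8-fold lower number from compound 2 to compound 3 (0.45 log units; beyond the scatter). The same chain in place of isopropyl gives a 1.5-fold lower number from compound 1 to compound 3 (0.19 log units; within the scatter), so compound 1 and compound 3 cannot be told apart, and the gain is seen only against the sec-butyl group of compound 2. Nothing available explains how this chain produces the step from sec-butyl.

The compounds shown leave open whether the diethylamino group or the length of the chain matters, a question that a plain hexyl chain or a shorter 2-(diethylamino)ethyl chain on the same oxygen could address. Also open, from the compounds shown here alone, is how a ring amine such as piperidine would compare with the diethylamino group at the end of the butyl chain.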